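Aryl variation on the aromatic nitrogen: toward compound 4

The source may hold more compounds than are shown below. What is called first, only, known or untested is meant among the compounds shown, and "the series" means these compounds.

Measured so far in a functional assay on A549 cells (Homo sapiens) for antiproliferative activity, read by MTT assay, with a stated time of 48 h; a lower number here means a stronger inhibitor, a higher number a weaker inhibitor:
- compound 1 `CCOc1ccc(-n2nncc2CN2C(=O)C3(C(C#N)=C(N)Oc4c3c3nc5ccccc5nc3c3ccccc43)c3ccccc32)cc1` gives 25200 nM.
- compound 2 `Cc1ccc(-n2nncc2CN2C(=O)C3(C(C#N)=C(N)Oc4c3c3nc5ccccc5nc3c3ccccc43)c3ccccc32)cc1C` reports > 50000 nM, a limit of the assay rather than a number.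
- compound 3 `Cc1ccc(-n2nncc2CN2C(=O)C3(C(C#N)=C(N)Oc4c(N)cc5nc6ccccc6nc5c43)c3ccccc32)cc1C` reports > 50000 nM, likewise a limit and not a number.

Compound 3 therefore stands at the limit of this assay, where two of the three values sit (the limit of > 50000 nM in this assay, at which 2 of the 3 values shown sit). Compound 2 and compound 3, which differ in the core and not in the aryl group, both show only that limit.

Compound 4 `COc1cc(-n2nncc2CN2C(=O)C3(C(C#N)=C(N)Oc4c(N)cc5nc6ccccc6nc5c43)c3ccccc32)c(OC)cc1Cl` is the next member. The change is 4-chloro-2,5-dimethoxyphenyl in place of 3,4-dimethylphenyl on an aromatic nitrogen. Among the compounds with values here, one measured step concerns the same position: an at least 1.9-fold higher number from compound 1 to compound 2 (0.29 log units; that floor lies within the scatter), a step that does not rise beyond the scatter. Within the data shown here, an aryl exchange on this nitrogen has thus so far produced no step of note, and nothing supports a movement off the limit.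

Compound 4 is accordingly expected to remain at or near the limit, with an estimated 60000 nM in this assay, a range from 20000 nM to 150000 nM, and an expected step that the limit leaves unreadable from compound 3 to compound 4.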

Compound 4, half-maximal inhibitory concentration: > 50000 nM
Compound 4 was reported as a limit; the forecaster's own chance of this, stated with the estimate: 70%; the middle value is on the limit's open side.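

In this assay compound 4 gives > 50000 nM, a limit and not a number. Within the data shown here, compound 3 gives > 50000 nM, also a limit, so no step between these two compounds can be read. The compounds shown leave open whether any aryl group on this nitrogen brings the core of compound 3 off the limit.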